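The compounds below may be only part of what the source reports. "The series", "measured", "known", "first", "only" and "open" are said of these compounds alone.

Compound 1 `CN1CCN(Cc2ccc(NC(=O)Nc3ccc4ncnc(Nc5cccc(C(F)(F)F)c5)c4c3)cc2)CC1` gives 2410 nM in a functional assay on A-431 cells (Homo sapiens) for antiproliferative activity, read by MTT assay, with a stated time of 72 h; a lower number here means a stronger inhibitor, a higher number a weaker inhibitor.
Compound 2 `CCN(CC)Cc1ccc(NC(=O)Nc2ccc3ncnc(Nc4cccc(C(F)(F)F)c4)c3c2)cc1` gives 3980 nM in this assay.
Compound 3 `O=C(Nc1ccccc1)Nc1ccc2ncnc(Nc3cccc(C(F)(F)F)c3)c2c1` gives > 10000 nM in this assay, and that value is a limit of the assay rather than a measured number.

Going by these compounds, compound 3 is therefore the weakest of the three, with steps to both others that are at least modest, though their true size is unknown because of the limit of > 10000 nM in this assay, at which 1 of the 3 values shown sits. Compound 4 `CN1CCN(CCNC(=O)Nc2ccc3ncnc(Nc4cccc(C(F)(F)F)c4)c3c2)CC1` differs from compound 3 by 2-(4-methylpiperazin-1-yl)ethyl in place of phenyl on an amide-type nitrogen. Among the measured compounds shown here, the steps that bear on this are an at least 4.1-fold higher number from compound 1 to compound 3 (0.61 log units; beyond the scatter) and an at least 2.5-fold higher number from compound 2 to compound 3 (0.40 log units; beyond the scatter): both remove an amine-bearing side chain and both lose potency. Compound 4 restores such a chain, though it gives up the phenyl ring, so the step of an at least 2.0-fold lower number from compound 3 to compound 4 (0.30 log units; that floor lies within the scatter) is expected to run toward a lower number, modestly. Compound 4 is thus estimated at 5000 nM, between 1500 nM and 20000 nM, in this assay.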

Compound 4, half-maximal inhibitory concentration: > 10000 nM
Compound 4 gave a limit, no number; the forecaster's own chance of this, stated with the estimate: 35%; middle value at least 2.0-fold (0.30 log units) from the limit.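

Compound 4 gives > 10000 nM in this assay, a limit of the assay and not a number. An amine-bearing chain on this amide-type nitrogen is therefore not enough to give a measurable value when no phenyl ring is present, and replacing the 4-((diethylamino)methyl)phenyl group with 2-(4-methylpiperazin-1-yl)ethyl gives an at least 2.5-fold higher number from compound 2 to compound 4 (0.40 log units; beyond the scatter). The step between compound 3 and compound 4 cannot be read because both values are limits: the limit of > 10000 nM in this assay, at which 2 of the 4 values shown sit.

Going by these compounds, it remains open whether the ring itself or the amine's placement matters more. A benzyl group or a longer chain ending in the same piperazine could help separate the two.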